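The source may report more compounds than this note shows. Statements on the series, on what has been measured and on what is new or still open speak of the compounds shown alone.

Working notes on the series. Compound 2 `COc1cc(-c2nn(-c3cccc(NC(=O)c4ccc(Cl)c(C(F)(F)F)c4)c3)cc2-c2ccncc2)ccc1Cl` has been run in a functional assay on HCT-116 cells (Homo sapiens) for inhibition, read by sulforhodamine B assay, with a stated time of 48 h; a higher number here means that more compound is tolerated, a lower number that less compound is tolerated; its value is a limit of the assay, and compound 2 gives > 32500 nM. Compound 1 `COc1cc(-c2nn(-c3cccc(NC(=O)Nc4ccc(Cl)c(Cl)c4)c3)cc2-c2ccncc2)ccc1Cl` is the other measured member; compound 1 gives > 50000 nM, likewise a limit. The step that the two limits leave unreadable from compound 1 to compound 2 is not readable; both of its ends sit at limits, the limit of > 32500 nM in this assay, at which 1 of the 2 values shown sits, and (the limit of > 50000 nM in this assay, at which 1 of the 2 values shown sits). Compound 3 `COc1cc(-c2nn(-c3cccc(NC(=O)Nc4ccc(Cl)c(C(F)(F)F)c4)c3)cc2-c2ccncc2)ccc1Cl` differs from compound 2 by (4-chloro-3-(trifluoromethyl)phenyl)amino in place of 4-chloro-3-(trifluoromethyl)phenyl on a carbonyl carbon. Among the compounds with values here, no measured step gives a readable size for such a change, so the step that the limit leaves unreadable from compound 2 to compound 3 is expected to be no readable change, most likely a limit again. Compound 3 is expected at 50000 nM, range 20000 nM to 200000 nM.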

Compound 3, concentration lethal to 50% of the cells: 21500 nM
For compound 3 the middle estimate is 2.3-fold (0.37 log units) above the measured one, within the range that was stated.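

At the carbonyl carbon, (4-chloro-3-(trifluoromethyl)phenyl)amino in place of 4-chloro-3-(trifluoromethyl)phenyl gives, in this assay, an at least 1.5-fold lower number from compound 2 to compound 3 (0.17 log units; that floor lies within the scatter), a floor that rests on a limit: the limit of > 32500 nM in this assay, at which 1 of the 3 values shown sits.

On an aromatic carbon, trifluoromethyl in place of chloro gives an at least 2.3-fold lower number from compound 1 to compound 3 (0.36 log units; beyond the scatter), the only floor here that clears the scatter, and it too rests on a limit: the limit of > 50000 nM in this assay, at which 1 of the 3 values shown sits.

On these data alone, the step between compound 1 and compound 2 cannot be read, and the true sizes of both floors stay open. As far as these compounds go, how a nitrile or a bromo group on that aromatic carbon would read also remains open.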